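A few compounds are considered here, and "the series" means these few. Any claim that something is new, unique, unknown or untested is made for them only; others in the source may bear on it.

Compound 1 `Cn1c(=O)c(S(=O)(=O)c2ccc(F)cc2)cc2cnc(Nc3ccc4cc[nH]c4c3)nc21`: 10000 nM
Compound 2 `Cn1c(=O)c(S(=O)(=O)c2ccccc2)cc2cnc(Nc3ccc4cc[nH]c4c3)nc21`: 10000 nM

In a functional assay on DU-145 cells (Homo sapiens) for inhibition, read by trypan blue exclusion, with a stated time of 72 h (on this read-out lower numbers stand for stronger inhibition and higher numbers for weaker inhibition), compound 1 gives 10000 nM, level with compound 2. Compound 3 `Cn1c(=O)c(S(=O)(=O)c2ccc(F)cc2)cc2cnc(Nc3ccc4[nH]cnc4c3)nc21` keeps the core of compound 1 and swaps one group: 1H-benzimidazol-5-yl in place of 1H-indol-6-yl on a nitrogen on an aromatic ring. Among the compounds with values here, the only measured step, hydrogen in place of fluoro on an aromatic carbon, is no change at the digits printed from compound 1 to compound 2 (within the scatter). Within the data shown here, it concerns a different part of the molecule, and no measured compound carries 1H-benzimidazol-5-yl. The data therefore point in no direction, and no shift beyond the scatter is expected in this assay. The expected step is no change at the digits printed from compound 1 to compound 3 (within the scatter). For compound 3 the estimated value is 10000 nM, with an expected range from 3000 nM to 30000 nM.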

Compound 3, half-maximal inhibitory concentration: 10000 nM
Estimate against measurement, compound 3: no gap at the digits printed; the measured number falls inside the stated range.
By their numbers in this assay, from the lowest: compounds 1, 2 and 3 (each within the scatter of the next).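

Placing 1H-benzimidazol-5-yl in place of 1H-indol-6-yl on a nitrogen on an aromatic ring, a place the earlier pair left unchanged, gives no change at the digits printed from compound 1 to compound 3 (within the scatter) in this assay. The hydrogen-bond acceptor counted on 1H-benzimidazol-5-yl, absent from 1H-indol-6-yl, therefore comes with no shift in this read-out. No evidence at hand bears on this result.

Going by these compounds, whether a phenyl carrying an amine or a carboxylic acid at this place would move the number remains open. With all three compounds level, nothing yet shows which change here, if any, alters the read-out.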